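This account rests on a few compounds, and the source may have more. Where it says the series, first, only, none or still open, it means among the compounds named here.

The measured compounds are compound 1 `COc1ccc(C(=O)O[C@H]2C=C(C)C(=O)C[C@@]3(C)CC[C@@](O)(C(C)C)[C@H]23)cc1` with 28600 nM in a functional assay on RS4-11 cells (Homo sapiens) for cytotoxicity, read by MTT assay, with a stated time of 72 h (a higher number here means a weaker inhibitor, a lower number a stronger inhibitor), compound 2 `CC1=C[C@H](OC(=O)c2ccc(O)cc2)[C@@H]2[C@](C)(CC[C@@]2(O)C(C)C)CC1=O` with 28200 nM, and compound 3 `COc1ccc(C(=O)O[C@H]2CC(C)=CC[C@@]3(C)CC[C@@](O)(C(C)C)[C@H]23)cc1` with 17600 nM.

Compound 2 differs from compound 1 by hydrogen in place of methyl on an oxygen on an aromatic ring, and this gave a 1.0-fold lower number from compound 1 to compound 2 (0.01 log units; within the scatter). Compound 3 sits at the lowest of the three numbers, but its gaps to compound 1 and compound 2 are both within the scatter, so no order among them can be claimed. How the core of compound 3 differs from that of compound 1 is not broken down here.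

Compound 4 `CC1=CC[C@@]2(C)CC[C@@](O)(C(C)C)[C@@H]2[C@@H](OC(=O)c2ccc(O)cc2)C1` is yet to be measured. It differs from compound 3 by hydrogen in place of methyl on an oxygen on an aromatic ring, the same change that separates compound 1 and compound 2. Since that step was flat, the expected step from compound 3 to compound 4 is a 1.0-fold lower number from compound 3 to compound 4 (0.00 log units; within the scatter), resting on compound 1 and compound 2 and their step of a 1.0-fold lower number from compound 1 to compound 2 (0.01 log units; within the scatter). Compound 4 is therefore estimated at 17500 nM.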

Compound 4, half-maximal inhibitory concentration: > 100000 nM
Compound 4 ended at the assay's limit; the forecaster's own chance of this, stated with the estimate: 10%; middle value at least 5.7-fold (0.75 log units) from the limit.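

In this assay compound 4 gives > 100000 nM, which is a limit of the assay and not a number. The change from methoxy to hydroxy gave an at least 5.6-fold higher number from compound 3 to compound 4 (0.75 log units; beyond the scatter), so its outcome on the core of compound 1 did not carry over to the core of compound 3: the same change on two cores in this assay, a 1.0-fold lower number (0.01 log units; within the scatter) from compound 1 to compound 2 and an at least 5.6-fold higher number (0.75 log units; beyond the scatter) from compound 3 to compound 4, at least 5.7-fold (0.76 log units) apart, beyond the scatter of two such steps. This rests on a single pair of cores, so it does not show which feature of the cores sets the outcome, nor the true size of the step on the core of compound 3.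

As far as these compounds go, whether an amine or a carboxylic acid in place of the hydroxy would follow the same split between the two cores remains open. So does the outcome of the methoxy to hydroxy change on any third core.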